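The compounds below may be only part of what the source reports. "The series", "measured", "known", "first", "only" and "open" are said of these compounds alone.

Compound 1, `CCC[C@@H](OC(C)=O)C1=C(Br)/C(=C/Br)OC1=O`: 2.1 ug/mL
Compound 2, `CCC[C@@H](OC(C)=O)C1=C(Br)[C@@](C)(OC)OC1=O`: 10.7 ug/mL

Of the compounds shown here, two have been measured in a functional assay on KB cells (Homo sapiens) for cytotoxicity; a lower number here means that less compound is needed, a higher number that more compound is needed for the effect. Compound 1 gives 2.1 ug/mL, the lower of the two numbers. Compound 2 gives 10.7 ug/mL, a higher number, and the gap between the two lies beyond the usual scatter of repeated measurements. Compound 3, `CCCCC1=C(Br)/C(=C/Br)OC1=O`, has not yet been measured. It differs from compound 1 in one place: hydrogen in place of acetoxy on a saturated chain carbon bound to a double-bonded ring carbon and a saturated chain carbon. For the measured compounds named here, no pair of measured compounds differs at this position, so the measured numbers give no direct guide to this change. Both measured compounds carry the acetoxy, and only compound 1 shares the rest of its core with compound 3. With nothing to anchor the change, a modest move to a higher number is expected, of a size that may still fall within the scatter. For compound 3 the expected value is 4 ug/mL, with a range from 1.5 ug/mL to 12 ug/mL. This estimate is expected to mean a 1.9-fold higher number from compound 1 to compound 3 (0.28 log units; within the scatter).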

Compound 3, concentration for half-maximal effect: > 20 ug/mL
Compound 3 gave a limit, no number; the forecaster's own chance of this, stated with the estimate: 5%; middle value at least 5.0-fold (0.69 log units) away from the limit.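

This step shows that the position is not a neutral one: in this assay, hydrogen in place of acetoxy on this saturated chain carbon gives an at least 9.5-fold higher number from compound 1 to compound 3 (0.97 log units; beyond the scatter). Compound 3 reads > 20 ug/mL, which is a limit of the assay and not a number. The true size of the step therefore stays unknown, because the value of compound 3 is only a limit: the limit of > 20 ug/mL in this assay, at which 1 of the 3 values shown sits.

The compounds shown leave open whether the acetoxy itself is needed, or whether a hydroxyl, an amine or a longer ester on this carbon would also keep the number near that of compound 1. They also leave open whether the same change would have a similar effect on the core of compound 2, which carries the acetoxy as well.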